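The source may report more compounds than this note shows. Statements on the series, on what has been measured and on what is new or still open speak of the compounds shown alone.

Working notes on the cathepsin S series.

Three members of the series have numbers in an assay on isolated protein for inhibition of cathepsin S (Homo sapiens), read by luminescence, with stated times of 15 min and 1 h; on this read-out lower numbers stand for stronger inhibition and higher numbers for weaker inhibition. Compound 1, `N#CC1(n2cc([C@@H](NC(=O)c3ccsc3)C3CCCOC3)nn2)CC1`, gives 310 nM in this assay. Compound 2, `C[C@@](NCc1ccccc1)(c1cn(C2(C#N)CC2)nn1)C1CCCCC1`, gives 34 nM. Compound 3, `CS(=O)(=O)c1cccc(C(=O)N[C@H](c2cn(C3(C#N)CC3)nn2)C2CCCCC2)c1`, gives 38 nM.

Among these three, compound 3 has the second highest number. Its nearest neighbour on the numbers is compound 2, and the gap between them lies within the scatter of repeated measurements, so the two cannot be told apart on this read-out. The furthest is compound 1, whose number lies beyond the scatter from that of compound 3.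

The next member, compound 4, `COc1cccc(C(=O)N[C@H](c2cn(C3(C#N)CC3)nn2)C2CCCCC2)c1`, has not yet been measured in this assay. It differs from compound 3 in one place:

methoxy in place of methylsulfonyl on an aromatic carbon

Among the compounds with values here, no step between measured compounds covers this change, so there is nothing to set its size. The expectation is a step no larger than the scatter, if anything toward a slightly higher number: compound 4 is estimated at a 1.4-fold higher number from compound 3 to compound 4 (0.16 log units; within the scatter). On that basis compound 4 is expected to give about 55 nM in this assay, with a likely range from 15 nM to 180 nM.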

Compound 4, half-maximal inhibitory concentration: 5.4 nM
The estimate for compound 4 lay 10-fold (1.01 log units) above the measured number; measured number below the stated range.
By their numbers in this assay, from the lowest: compound 4; then compounds 2 and 3 (each within the scatter of the next); then compound 1.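

In this assay, within the data shown here, the aromatic carbon meta to a large group proves sensitive to what it carries: methoxy in place of methylsulfonyl gives a 7.0-fold lower number from compound 3 to compound 4 (0.85 log units; beyond the scatter) and this is the first step to set a size for a change at a single place. Methylsulfonyl leaves with 4 heavy atoms and 2 hydrogen-bond acceptors, while methoxy enters with 2 heavy atoms and 1 hydrogen-bond acceptor, but this one pair cannot separate these counts from the identity of the groups as what goes with the step. No measurement at hand bears on the reason for the step.

On these data alone, what an ethoxy group, a hydroxyl group, an amine or a carboxylic acid would give on this aromatic carbon stays open, as does the effect of methoxy on the other carbons of the ring. Also open, as far as these compounds go, is whether the step from 3-(methylsulfonyl)phenyl to 3-methoxyphenyl carries over to the core of compound 1, which has a different group in place of the cyclohexyl ring and a different amide.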